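A Methoxy Group on a Weakly Active Core

The source may hold more compounds than are shown below. What is called first, only, known or untested is meant among the compounds shown, and "the series" means these compounds.

Compound 1 `O=c1c(CSC(=S)N2CCCC2)coc2ccccc12` shows little activity. In a functional assay on MCF7 cells (Homo sapiens) for antiproliferative activity, read by MTT assay, with a stated time of 72 h (a lower number here means a stronger inhibitor, a higher number a weaker inhibitor), compound 1 reaches only the limit of the measurement, > 25000 nM, so no number is known for it. Compound 2 `Cc1ccc2c(=O)c(CSC(=S)N3CCCC3)coc2c1` carries an added methyl group and gives 41400 nM in this assay. The step that the limit leaves unreadable from compound 1 to compound 2 cannot be sized because the limit of > 25000 nM in this assay, at which 1 of the 2 values shown sits, hides the starting value. Compound 3 `COc1ccc2occ(CSC(=S)N3CCCC3)c(=O)c2c1` differs from compound 1 by methoxy in place of hydrogen on an aromatic carbon. Within the data shown here, no measured step reads cleanly, so no shift beyond the scatter is expected. The step that the limit leaves unreadable from compound 1 to compound 3 is therefore an estimate only. Compound 3 is expected to give 35000 nM, within 12000 nM to 100000 nM.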

Compound 3, half-maximal inhibitory concentration: 34100 nM
The estimate for compound 3 lay 1.0-fold (0.01 log units) above the measured number; the measured number falls inside the stated range.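

No new step can be read from compound 1 to compound 3, because compound 1 has no number, only a limit: the limit of > 25000 nM in this assay, at which 1 of the 3 values shown sits.

From the compounds shown here alone, whether methoxy or methyl in place of hydrogen changes the activity of the shared core in this assay stays open.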